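Replacing bromo with trifluoromethyl in compound 3

This account rests on a few compounds, and the source may have more. Where it says the series, first, only, none or still open, it means among the compounds named here.

Measured in a functional assay on LOX IMVI cells (Homo sapiens) for cytotoxicity, read by MTT assay, with a stated time of 24 h; on this read-out lower numbers stand for stronger inhibition and higher numbers for weaker inhibition:
Compound 1 `O=S(=O)(NCCCNc1nccc(-c2[nH]c(-c3ccccc3)nc2-c2ccc(F)c(O)c2)n1)c1ccc(C(F)(F)F)cc1`: 2450 nM
Compound 2 `O=S(=O)(NCCCNc1nccc(-c2[nH]c(-c3ccccc3)nc2-c2ccc(Cl)c(O)c2)n1)c1ccccc1`: 2630 nM
Compound 3 `O=S(=O)(NCCCNc1nccc(-c2[nH]c(-c3ccccc3)nc2-c2ccc(Cl)c(O)c2)n1)c1ccc(Br)cc1`: 15500 nM

Of these three, compound 3 has the highest number, 15500 nM, and so the weakest inhibition, with the values of both other compounds lying lower by more than the scatter. Compound 4 `O=S(=O)(NCCCNc1nccc(-c2[nH]c(-c3ccccc3)nc2-c2ccc(Cl)c(O)c2)n1)c1ccc(C(F)(F)F)cc1` is the next to be tested in this assay. It replaces the bromo of compound 3 with trifluoromethyl on an aromatic carbon: trifluoromethyl in place of bromo on an aromatic carbon.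

For the measured compounds named here, no measured step makes this exchange directly. The nearest evidence is a 5.9-fold higher number from compound 2 to compound 3 (0.77 log units; beyond the scatter), a modest step for bromo in place of hydrogen on an aromatic carbon. It shows what introducing bromo did, not what trifluoromethyl will do. Going by the values given here, compound 1, the only measured compound bearing trifluoromethyl, gives 2450 nM, which suggests that this group is compatible with a lower number. A modest move downward is therefore expected, and the expected change is a 2.8-fold lower number from compound 3 to compound 4 (0.45 log units; beyond the scatter). For compound 4 the estimated value is 5500 nM, with an expected range of 2000 nM to 15000 nM.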

Compound 4, half-maximal inhibitory concentration: 10100 nM
The estimate for compound 4 lay 1.8-fold (0.26 log units) below the measured number; low and high end bracket the measured number.
By their numbers in this assay, from the lowest: compounds 1 and 2 (each within the scatter of the next); then compounds 4 and 3 (each within the scatter of the next).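

In this assay there is a 1.5-fold lower number from compound 3 to compound 4 (0.19 log units; within the scatter) so trifluoromethyl and bromo cannot be told apart at this position. Set against hydrogen, trifluoromethyl gives a 3.8-fold higher number from compound 2 to compound 4 (0.58 log units; beyond the scatter) and so goes the same way as bromo, leaving hydrogen with the lowest number among the three chloro compounds, compound 2, compound 3 and compound 4. The low number of compound 1 does not come with trifluoromethyl alone: with that group kept, the data show a 4.1-fold higher number from compound 1 to compound 4 (0.62 log units; beyond the scatter) on exchanging the halogen elsewhere in the molecule.

Going by these compounds, whether an amine, a carboxylic acid or a methoxy group at this position would return to the level of compound 2 stays open, as does whether fluoro in place of chloro also lowers the number when this position carries hydrogen or bromo. Nothing measured alongside these numbers gives a reason for these shifts.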